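The source may hold more compounds than are shown below. What is called first, only, known or untested is meant among the compounds shown, and "the series" means these compounds.

Of the compounds shown here, three sharing one core have been measured. Compound 1 `CCc1ccc(C(=O)N2CCN(Cc3nc4ccccc4n3Cc3cccc(C)c3)CC2)cc1` gives 67% in an assay on isolated protein for inhibition of aldehyde dehydrogenase 1A1 (Homo sapiens), read by spectrophotometry, tested at 10 uM; on this read-out higher numbers stand for more inhibition at the one concentration tested (going by the name of the read-out) and lower numbers for less inhibition. Compound 2 `Cc1cccc(Cn2c(CN3CCN(C(=O)C4CCCCC4)CC3)nc3ccccc32)c1` gives 31.9% in this assay, and compound 3 `Cc1cccc(Cn2c(CN3CCN(C(=O)C(C)C)CC3)nc3ccccc32)c1` gives 87.2%. Compound 3 stands highest of the three: the step of a number 20.2 percentage points higher from compound 1 to compound 3 (beyond the scatter) is modest, and the step of a number 55.3 percentage points higher from compound 2 to compound 3 (beyond the scatter) is large, so compound 3 lies beyond the scatter above both other compounds.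

Compound 4 `Cc1cccc(Cn2c(CN3CCN(C(=O)C4CCC4)CC3)nc3ccccc32)c1` has not yet been measured. It differs from compound 3 in one place: cyclobutyl in place of isopropyl on a carbonyl carbon. The two measured steps into compound 3 bear on this change, since both swap the group on the carbonyl carbon. Going from cyclohexyl to isopropyl raised the number by a number 55.3 percentage points higher from compound 2 to compound 3 (beyond the scatter), and going from 4-ethylphenyl to isopropyl by a number 20.2 percentage points higher from compound 1 to compound 3 (beyond the scatter). Cyclobutyl is a ring of four carbon atoms, a smaller ring than cyclohexyl, so a drop from compound 3 is expected, but a smaller one than the reverse of the step from compound 2. The step from compound 3 to compound 4 is therefore expected to be a number 22.2 percentage points lower from compound 3 to compound 4 (beyond the scatter) in this assay. Compound 4 is estimated at 65%, with a range from 40% to 88%.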

Compound 4, a percentage reported as inhibition, at one concentration (the size of the read-out at that concentration, not a potency): 69.1%
The estimate for compound 4 lay 4.1 percentage points below the measured number; the range from low to high includes it.
By their numbers in this assay, from the lowest: compound 2; then compounds 1 and 4 (each within the scatter of the next); then compound 3.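

In this assay, the swap from isopropyl to cyclobutyl on the carbonyl carbon gives a number 18.1 percentage points lower from compound 3 to compound 4 (beyond the scatter), whereas the swap from cyclohexyl to cyclobutyl gives a number 37.2 percentage points higher from compound 2 to compound 4 (beyond the scatter), so among these three non-aromatic groups the number depends on which group is present and not simply on whether it has a ring. Compounds 3, 4 and 2 fall in order as the group goes from isopropyl to cyclobutyl to cyclohexyl, but compound 1 does not fit a simple trend with group size, since the change to cyclobutyl gives a number 2.1 percentage points higher from compound 1 to compound 4 (within the scatter). Nothing available explains these differences.

The compounds shown leave open where cyclopropyl, cyclopentyl or tert-butyl would fall in this series. They also leave open whether a ring containing oxygen, such as tetrahydropyranyl, would behave like cyclohexyl on the carbonyl carbon.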